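The source may report more compounds than this note shows. Statements on the series, on what has been measured and on what is new or still open speak of the compounds shown alone.

Compound 1 `COc1ccc(OC)c(C(=O)/C=C/c2ccc(C(=O)OCC=C(C)C)cc2)c1`: > 50000 nM (a limit)
Compound 2 `CCCNC(=O)c1ccc(/C=C/C(=O)c2cc(OC)ccc2OC)cc1`: 1500 nM

Among the measured compounds shown here, in a functional assay on PC-3 cells (Homo sapiens) for cytotoxicity, read by MTT assay, with a stated time of 72 h (a higher number here means a weaker inhibitor, a lower number a stronger inhibitor), compound 2 gives 1500 nM as the only actual number so far. Compound 1 reports > 50000 nM as a limit and not a number. The change isopropyl in place of propyl on an amide-type nitrogen turns compound 2 into compound 3 `COc1ccc(OC)c(C(=O)/C=C/c2ccc(C(=O)NC(C)C)cc2)c1` and puts isopropyl in place of propyl on an amide-type nitrogen. For the measured compounds named here, the only measured step of an at least 33-fold lower number from compound 1 to compound 2 (1.52 log units; beyond the scatter) swapped a whole group on a carbonyl carbon, so it is a poor guide to this exchange of propyl for isopropyl. The expected step of a 1.1-fold higher number from compound 2 to compound 3 (0.03 log units; within the scatter) is therefore none beyond the scatter. For compound 3 the estimate is 1600 nM with an expected range from 600 nM to 4500 nM in this assay.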

Compound 3, half-maximal inhibitory concentration: 1580 nM
Beside the measured number, compound 3's estimate is 1.0-fold (0.01 log units) above it, within the range that was stated.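

Putting isopropyl in place of propyl on the amide-type nitrogen gives a 1.1-fold higher number from compound 2 to compound 3 (0.02 log units; within the scatter), so branching this small chain makes no measurable difference here. The large step seen with propylamino also appears with isopropylamino in place of (3-methylbut-2-en-1-yl)oxy, with an at least 31-fold lower number from compound 1 to compound 3 (1.50 log units; beyond the scatter). Compound 1 carries a limit and not a number: the limit of > 50000 nM in this assay, at which 1 of the 3 values shown sits.

Still open, on these data alone, is whether a longer chain such as hexyl, or a benzyl group, on that nitrogen would hold this level. A carboxylic acid on the same carbonyl carbon also remains untested among the compounds shown.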